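Moving the Trifluoromethyl on the Phenyl Arm of Compound 2

The source may hold more compounds than are shown below. What is called first, only, known or untested is meant among the compounds shown, and "the series" means these compounds.

Compound 1 `CN(C(=O)NC(=O)c1ccc(F)c(F)c1)c1nc(C(F)(F)F)c(C(=O)N/N=C/c2ccc(C(F)(F)F)cc2)s1`: in a functional assay on HeLa cells (Homo sapiens) for inhibition, read by MTT assay, with a stated time of 72 h (a higher number here means a weaker inhibitor, a lower number a stronger inhibitor), compound 1 gives 5.1 ug/mL.
Compound 2 `CN(C(=O)NC(=O)c1ccc(Cl)cc1Cl)c1nc(C(F)(F)F)c(C(=O)N/N=C/c2cccc(C(F)(F)F)c2)s1`: in this assay compound 2 gives 9.6 ug/mL.
Compound 3 `CNc1nc(C)c(C(=O)N/N=C/c2ccccc2C(F)(F)F)s1`: in this assay compound 3 reaches only a limit of > 100 ug/mL.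

Compound 2 holds the higher of the two numbers given, but its gap to compound 1 lies within the scatter of this assay, so no order can be read from it. Compound 4 `CN(C(=O)NC(=O)c1ccc(Cl)cc1Cl)c1nc(C(F)(F)F)c(C(=O)N/N=C/c2ccc(C(F)(F)F)cc2)s1` keeps the same atoms as compound 2 and differs only in one place: 4-(trifluoromethyl)phenyl in place of 3-(trifluoromethyl)phenyl on a carbon with a double bond to nitrogen. Among the compounds with values here, no measured pair covers this exact change, and compound 1 carries the same arm together with a different other half, so the expected step of a 1.4-fold lower number from compound 2 to compound 4 (0.14 log units; within the scatter) in this assay is none beyond the scatter. Compound 4 is therefore estimated at 7 ug/mL, between 3 ug/mL and 20 ug/mL.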

Compound 4, half-maximal inhibitory concentration: 7.99 ug/mL
Beside the measured number, compound 4's estimate is 1.1-fold (0.06 log units) below it, and the stated range covers the measured number.
By their numbers in this assay, from the lowest: compounds 1, 4 and 2 (each within the scatter of the next). At a limit, above all of these: compound 3.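

With a 1.2-fold lower number from compound 2 to compound 4 (0.08 log units; within the scatter) in this assay for 4-(trifluoromethyl)phenyl in place of 3-(trifluoromethyl)phenyl, the two arms cannot be told apart at this place on a carbon with a double bond to nitrogen. The other half gives the same reading, with a 1.6-fold higher number from compound 1 to compound 4 (0.19 log units; within the scatter) for 2,4-dichlorophenyl in place of 3,4-difluorophenyl on a carbonyl carbon. Nothing measured here bears on why these steps are so small.

The compounds shown leave open whether a carboxylic acid or an amine in place of the trifluoromethyl on this arm would give a step beyond the scatter.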